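Swapping a Ring on a Triple-Bond Chain

A few compounds are considered here, and "the series" means these few. Any claim that something is new, unique, unknown or untested is made for them only; others in the source may bear on it.

Compound 1 `CN(C)C(=O)N(C)CC#CCN1CCCC1` carries a pyrrolidin-1-yl group on a saturated chain carbon bound to a triple-bonded carbon. In a functional assay on the whole organism for antagonist activity, with Mus musculus as the target (a lower number here means that less compound is needed, a higher number that more compound is needed for the effect), compound 1 gives only a limit, > 10 mg/kg. Compound 2 `CN(C)C(=O)N(C)CC#CCn1ccnc1` differs from it by 1H-imidazol-1-yl in place of pyrrolidin-1-yl on a saturated chain carbon bound to a triple-bonded carbon. In this assay compound 2 likewise gives only a limit, > 100 mg/kg. The resulting step, a step that the two limits leave unreadable from compound 1 to compound 2, therefore cannot be sized. Compound 3 `Cn1ccn(CC#CCN2CCCC2)c1=O` has another core; how it differs from compound 1 is not broken down here. In this assay compound 3 gives only a limit, > 10 mg/kg. Compound 4 `Cn1ccn(CC#CCn2ccnc2)c1=O`, not yet measured, differs from compound 3 by 1H-imidazol-1-yl in place of pyrrolidin-1-yl on a saturated chain carbon bound to a triple-bonded carbon, the same change as before. Among the measured compounds shown here, the step is expected to be a step that the limit leaves unreadable from compound 3 to compound 4, beside a step that the two limits leave unreadable from compound 1 to compound 2, and this expectation rests on the limit of > 10 mg/kg in this assay, at which 2 of the 3 values shown sit, and (the limit of > 100 mg/kg in this assay, at which 1 of the 3 values shown sits), since every value so far is a limit. Compound 4 is expected to give 100 mg/kg.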

Compound 4, dose for half-maximal effect: > 100 mg/kg
Compound 4: no number, only a limit; the forecaster's own chance of this, stated with the estimate: 85%; the middle value lies on the limit itself.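

In this assay compound 3 and compound 4 each give only a limit, so the size of the swap from pyrrolidin-1-yl to 1H-imidazol-1-yl cannot be read. The compounds shown leave open whether this swap changes the dose needed at all.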